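A few compounds are considered here, and "the series" means these few. Any claim that something is new, unique, unknown or untested is made for them only; others in the source may bear on it.

Three compounds share one core and are set apart by the group carried on an aromatic carbon of that core. Compound 1 `COc1cc(NC(C)CCCNC(=O)C2CCC3(CC2)OOC2(OO3)C3CC4CC(C3)CC2C4)c2ncccc2c1-c1ccc(Cl)cc1` carries a 4-chlorophenyl there, and in an ADME assay on microsomes from liver (Rattus norvegicus) for metabolic stability, read by HPLC, using NADPH, tested at 1 mM (a higher number here means faster removal of the compound, a lower number slower removal), compound 1 gives 10.7 uL/min. Compound 2 `COc1cc(NC(C)CCCNC(=O)C2CCC3(CC2)OOC2(OO3)C3CC4CC(C3)CC2C4)c2ncccc2c1-c1ccsc1` carries a thiophen-3-yl, and in this assay compound 2 gives 37.4 uL/min; the step of a 3.5-fold higher number from compound 1 to compound 2 (0.54 log units; beyond the scatter). Compound 3 `COc1cc(NC(=O)C2CCC3(CC2)OOC2(OO3)C3CC4CC(C3)CC2C4)c2ncccc2c1-c1ccccc1` carries a phenyl, and in this assay compound 3 gives 33 uL/min. Compound 3 thus stands second highest of the three numbers: its value lies within the scatter of that of compound 2, while it sits beyond the scatter above that of compound 1, which gives the lowest number of the three.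

Compound 4 `COc1cc(NC(=O)C2CCC3(CC2)OOC2(OO3)C3CC4CC(C3)CC2C4)c2ncccc2c1-c1ccc(Cl)cc1` differs from compound 3 by chloro in place of hydrogen on an aromatic carbon. Among the compounds with values here, no measured pair shows this exact change. Within the data shown here, the one step that involves a 4-chlorophenyl is a 3.5-fold higher number from compound 1 to compound 2 (0.54 log units; beyond the scatter), a modest step beyond the scatter, and the compound carrying that group, compound 1, gives the lowest number measured. On that basis a modest step down in this assay is expected for compound 4, namely a 2.1-fold lower number from compound 3 to compound 4 (0.31 log units; beyond the scatter), though the link to the core differs from that in compound 1, so the range is kept wide. Compound 4 is therefore estimated at 16 uL/min, between 7 uL/min and 36 uL/min.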

Compound 4, intrinsic clearance in a liver preparation (reported as CLH), per the amount of preparation that the assay uses: 11.1 uL/min
The estimate for compound 4 lay 1.4-fold (0.16 log units) above the measured number; low and high end bracket the measured number.
By their numbers in this assay, from the lowest: compounds 1 and 4 (each within the scatter of the next); then compounds 3 and 2 (each within the scatter of the next).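

Adding a single chloro to the phenyl, para to a large group, is enough on its own to move the number in this assay, with a 3.0-fold lower number from compound 3 to compound 4 (0.47 log units; beyond the scatter). Within the data shown here, this gives the first direct reading of the change, since the earlier step from 4-chlorophenyl to thiophen-3-yl swapped the whole ring and could not isolate the chlorine atom. The two compounds carrying 4-chlorophenyl differ only in the link to the core, and compound 1 at 10.7 uL/min and compound 4 at 11.1 uL/min lie within the scatter of each other, so in this pair the chain in compound 1 leaves the number unmoved; nothing shown here accounts for the effect of the chloro itself.

From the compounds shown here alone, whether fluoro, methoxy or an amine at this place on the phenyl would shift the number as chloro does remains open. Going by these compounds, it is also open whether chloro has an effect of the same size when the core bears the longer chain of compound 1.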